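The source may report more compounds than this note shows. Statements on the series, on what has been measured and on what is new or still open speak of the compounds shown alone.

Series: compound 1 `CSc1nc(NCCCCCO)c2ccccc2n1`, compound 2 `CCCCC[Se]c1nc(NCc2ccccc2)c2ccccc2n1`, compound 3 `[SeH]c1nc(NCc2ccccc2)c2ccccc2n1` and the not yet measured compound 4 `CSc1nc(NCc2ccccc2)c2ccccc2n1`. In a functional assay on MCF7 cells (Homo sapiens) for cytotoxicity, read by MTT assay, with a stated time of 72 h (on this read-out higher numbers stand for weaker inhibition of growth and lower numbers for stronger inhibition of growth), compound 2 gives 50 nM, and compound 1 gives 62000 nM. For compound 3 only a limit is recorded, > 100000 nM (the limit of > 100000 nM in this assay, at which 1 of the 3 values shown sits); compound 3 thus stands apart from the numbered values of compound 1 and compound 2. The change from compound 3 to compound 4 is a group of 2 heavy atoms (1 carbon, 1 sulfur; no ring) in place of one selenium atom, on an aromatic carbon. Going by the values given here, the one measured step touching this position is an at least 2000-fold higher number from compound 2 to compound 3 (3.30 log units; beyond the scatter), where loss of pentyl on the selenium removed measurable inhibition; the present change runs the other way, though methylsulfanyl is a shorter group than pentyl and a different chalcogen, and compound 1 with methylsulfanyl gives only 62000 nM. Compound 4 is therefore estimated at 5000 nM, range 500 nM to 50000 nM. This estimate implies an expected step of an at least 20-fold lower number from compound 3 to compound 4 (1.30 log units; beyond the scatter).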

Compound 4, concentration for 50% growth inhibition: 41500 nM
The estimate for compound 4 lay 8.3-fold (0.92 log units) below the measured number; the measured number falls inside the stated range.
By their numbers in this assay, from the lowest: compound 2; then compounds 4 and 1 (each within the scatter of the next). At a limit, above all of these: compound 3.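

In this assay, methylsulfanyl at this place gives only a modest gain over selenium alone, an at least 2.4-fold lower number from compound 3 to compound 4 (0.38 log units; beyond the scatter), and this step rests on a limit. Against the pentyl group on selenium there is an 830-fold higher number from compound 2 to compound 4 (2.92 log units; beyond the scatter), so strong inhibition of growth does not follow from just any chalcogen substituent here. With methylsulfanyl in place, phenyl in place of 4-hydroxybutyl gives a 1.5-fold lower number from compound 1 to compound 4 (0.17 log units; within the scatter).

The compounds shown do not separate the pentyl chain from the selenium atom. A pentylsulfanyl or a methylselanyl group at this place would separate the two.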